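The source may report more compounds than this note shows. Statements on the series, on what has been measured and on what is new or still open speak of the compounds shown alone.

Measured so far in an ADME assay on Vero cells (Chlorocebus sabaeus) for cytotoxicity, read by MTT assay; a higher number here means that more compound is tolerated, a lower number that less compound is tolerated:

- compound 1 (`O=c1[nH]c(=O)n([C@@H]2O[C@H](CO)[C@@H](O)[C@H]2O)cc1C#CC1CCCCC1`): 148000 nM
- compound 2 (`O=c1[nH]cc(C#CC2CCCCC2)c(=O)[nH]1`): 247000 nM

Compound 1, at 148000 nM, lies within the usual scatter of compound 2, at 247000 nM, so these two numbers do not separate the pair. Among the compounds with values here, compound 1 therefore stands level with the only other compound measured so far.

Compound 3 (`CCCCCCC#Cc1cn([C@@H]2O[C@H](CO)[C@@H](O)[C@H]2O)c(=O)[nH]c1=O`) has not yet been measured in this assay. Its difference from compound 1 is this: hexyl in place of cyclohexyl on a triple-bonded carbon. The rest of the structure stays the same.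

Within the data shown here, no measured pair of compounds differs in one place, so the data offer no direct precedent for this change. The expectation rests only on the closeness of the two measured numbers, with compound 1 at 148000 nM as the starting point. No step beyond the scatter is expected in this assay, and no firm direction can be given. The estimated change is small, a 1.1-fold lower number from compound 1 to compound 3 (0.06 log units; within the scatter). For compound 3 the expected value is 130000 nM, with an estimated range of 60000 nM to 280000 nM.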

Compound 3, half-maximal cytotoxic concentration: 111000 nM
Compound 3: the middle estimate sits 1.2-fold (0.07 log units) above what was measured; the range from low to high includes it.
By their numbers in this assay, from the lowest: compounds 3, 1 and 2 (each within the scatter of the next, the first and the last beyond it).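

In this assay, within the data shown here, the exchange of cyclohexyl for hexyl on the triple-bonded carbon gives the first direct reading of a change at this position: a 1.3-fold lower number from compound 1 to compound 3 (0.12 log units; within the scatter). The two groups have the same count of carbon atoms, and one has a six-membered ring of carbon only while the other has no ring, so for this pair the ring makes no difference that this assay can resolve on the shared core. Nothing on hand offers an explanation for this result.

Still open, as far as these compounds go, is whether the numbers would stay this close with a much longer chain, a short chain such as propyl, or a chain ending in an amine or a carboxylic acid at this place. This single pair also cannot show whether hexyl and cyclohexyl would read alike on a different core, so it sets no general rule for the position.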